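The source may report more compounds than this note shows. Statements on the series, on what has been measured and on what is new or still open speak of the compounds shown alone.

Compound 1, `C=C[C@@H]1OC(CCCCC)=N[C@H]1CO`: in an assay on isolated protein for inhibition of matrix metalloproteinase-9 (Homo sapiens) (a higher number here means a weaker inhibitor, a lower number a stronger inhibitor), compound 1 gives > 2000000 nM, which is a limit of the assay and not a number.
Compound 2, `C=C[C@@H]1OC(c2ccc(Oc3ccccc3)cc2)=N[C@H]1CO`: in this assay compound 2 gives 32000 nM.
Compound 3, `C=C[C@@H]1OC(c2ccc(C)cc2)=N[C@H]1CO`: in this assay compound 3 gives 68000 nM.

Among the numbers shown, compound 3 stands highest of the two, with compound 2 nearest; compound 1 sits only at the limit of > 2000000 nM in this assay, at which 1 of the 3 values shown sits. Among the measured compounds shown here, the single measured step between them, a 2.1-fold higher number from compound 2 to compound 3 (0.33 log units; beyond the scatter), shows that putting methyl in the place of phenoxy made the inhibitor somewhat weaker.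

Compound 4, `C=C[C@@H]1OC(c2ccc(-c3ccccc3)cc2)=N[C@H]1CO`, differs from compound 3 by phenyl in place of methyl on an aromatic carbon. It is the step from compound 2 to compound 3 that bears on this change: there methyl replaced phenoxy and the number rose by a modest amount, whereas here methyl is in turn replaced by phenyl. The expected outcome is therefore a modest fall in the number, of about a 2.4-fold lower number from compound 3 to compound 4 (0.39 log units; beyond the scatter), and compound 4 is estimated at 28000 nM, within a range of 9000 nM to 85000 nM.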

Compound 4, inhibition constant: 24000 nM
The estimate for compound 4 lay 1.2-fold (0.07 log units) above the measured number; measured number inside the range.
By their numbers in this assay, from the lowest: compounds 4 and 2 (each within the scatter of the next); then compound 3. At a limit, above all of these: compound 1.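

In this assay the swap on this aromatic carbon gave a 2.8-fold lower number from compound 3 to compound 4 (0.45 log units; beyond the scatter), which adds a second case to the earlier one: both steps away from or back to methyl lie beyond the scatter, and methyl is the group with the higher number. The step of a 1.3-fold lower number from compound 2 to compound 4 (0.12 log units; within the scatter) lies within the scatter, so phenyl and phenoxy cannot be told apart at this place, and the oxygen atom that links the phenoxy ring shows no measurable effect on the number here. Nothing shown here gives a cause for either step.

The compounds shown leave open how a ring-bearing group with an amine or a carboxylic acid on its outer ring would fare at this place. They also leave open whether a longer chain of aromatic rings would lower the number any further.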